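This account rests on a few compounds, and the source may have more. Where it says the series, first, only, none or still open, it means among the compounds named here.

Working notes on the series. Compound 1 `COc1ccc(C(=O)C2Sc3nnc(-c4cc(OC)c(OC)c(OC)c4)n3NC2c2cccs2)cc1` gives 95900 nM in a functional assay on PC-3 cells (Homo sapiens) for cytotoxicity, read by MTT assay, with a stated time of 48 h; on this read-out higher numbers stand for weaker inhibition and lower numbers for stronger inhibition. Compound 2 `COc1cc(-c2nnc3n2NC(c2ccco2)C(C(=O)c2cccs2)S3)cc(OC)c1OC` gives 46200 nM in the same assay, and compound 3 `COc1cc(-c2nnc3n2NC(c2cccs2)C(C(=O)c2ccc(Cl)cc2)S3)cc(OC)c1OC` gives 32500 nM. Compound 2 thus stands second highest of the three numbers: its value and that of compound 3 lie within the scatter of each other, while compound 1 sits beyond the scatter above it. For the measured compounds named here, the single one-place step measured so far, a 3.0-fold lower number from compound 1 to compound 3 (0.47 log units; beyond the scatter), concerns the group on the carbonyl carbon and is modest.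

Compound 4 `COc1cc(-c2nnc3n2NC(c2ccco2)C(C(=O)c2cccc4ccccc24)S3)cc(OC)c1OC` differs from compound 2 in one place: naphthalen-1-yl in place of thiophen-2-yl on a carbonyl carbon. Going by the values given here, no measured step swaps the aromatic ring on the carbonyl carbon for a larger one, so the step from compound 1 to compound 3 is the only guide to how much a change at that position can move the read-out in this assay, and it suggests a modest step at most. Compound 4 is therefore expected to move by a 1.3-fold lower number from compound 2 to compound 4 (0.12 log units; within the scatter) toward a slightly lower number, with little confidence in direction. The estimated value for compound 4 is 35000 nM, within a range of 12000 nM to 100000 nM.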

Compound 4, half-maximal inhibitory concentration: > 100000 nM
Compound 4: a limit, no number; the forecaster's own chance of this, stated with the estimate: 10%; at least 2.8-fold (0.45 log units) between middle value and limit.
By their numbers in this assay, from the lowest: compounds 3 and 2 (each within the scatter of the next); then compound 1. At a limit, above all of these: compound 4.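

For the compounds shown here, the step of an at least 2.1-fold higher number from compound 2 to compound 4 (0.33 log units; beyond the scatter) shows that the group on this carbonyl carbon can also push the number up, whereas the only earlier step at this carbon, a 3.0-fold lower number from compound 1 to compound 3 (0.47 log units; beyond the scatter), ran toward a lower number. The two steps start from different compounds, but together they show that changes at this carbon can move the read-out in this assay in either direction. The result for compound 4 is a limit of the assay and not a number: the limit of > 100000 nM in this assay, at which 1 of the 4 values shown sits.

On these data alone, how far compound 4 lies past that limit stays open, so its step has only a lower bound and no true size. Also open, as far as these compounds go, is whether a saturated amine such as piperidin-1-yl, or a longer alkyl chain, on a carbonyl carbon would keep the read-out near that of compound 2.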